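Trifluoromethoxy in place of fluoro on a shared core

The source may hold more compounds than are shown below. What is called first, only, known or untested is meant among the compounds shown, and "the series" means these compounds.

Three compounds sharing one core were measured in an assay on isolated protein for inhibition of DNA topoisomerase 1 (Homo sapiens), with a stated time of 30 min, tested at 20 uM; on this read-out lower numbers stand for a weaker effect and higher numbers for a stronger effect at the one concentration tested. Compound 1 `Cc1ccc2nc(-c3cccc(C(F)(F)F)c3)[nH]c(=O)c2c1` gives 4.2%. Compound 2 `COc1cccc(-c2nc3ccc(C)cc3c(=O)[nH]2)c1` gives 0%. Compound 3 `Cc1ccc2nc(-c3cccc(F)c3)[nH]c(=O)c2c1` gives 0.2%, the second highest of the three numbers, though its separations from both neighbours fall inside the usual scatter. The steps among them are small: a number 4.2 percentage points lower from compound 1 to compound 2 (within the scatter), a number 4 percentage points lower from compound 1 to compound 3 (within the scatter), and a number 0.2 percentage points higher from compound 2 to compound 3 (within the scatter).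

Compound 4 `Cc1ccc2nc(-c3cccc(OC(F)(F)F)c3)[nH]c(=O)c2c1` has not yet been measured. It differs from compound 3 in one place: trifluoromethoxy in place of fluoro on an aromatic carbon. For the measured compounds named here, the steps that bear on this change are the two that end at compound 3, each swapping a group on the same aromatic carbon, and both stayed inside the scatter; the swap from trifluoromethyl in compound 1 and the swap from methoxy in compound 2 left the read-out in this assay near zero. With all three measured compounds showing only weak effects at the one concentration tested, the expectation for compound 4 is a step of no meaningful size, a number 1.8 percentage points higher from compound 3 to compound 4 (within the scatter), in this assay. Compound 4 is therefore estimated at 2% in this assay, with a range from 0% to 10%.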

Compound 4, a percentage reported as inhibition, at one concentration (the size of the read-out at that concentration, not a potency): 0%
Estimate against measurement, compound 4: 2 percentage points above; measured number inside the range.
By their numbers in this assay, from the lowest: compounds 2, 4, 3 and 1 (each within the scatter of the next).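

In this assay, the change at this aromatic carbon, meta to a large group, from fluoro to trifluoromethoxy brings in 5 heavy atoms where fluoro has 1, yet it gives a number 0.2 percentage points lower from compound 3 to compound 4 (within the scatter), so this larger substituent adds to the picture without separating from the smaller one. The two closest comparisons point the same way: trifluoromethyl in place of methyl on the oxygen gives no change at the digits printed from compound 2 to compound 4 (within the scatter), and trifluoromethoxy in place of trifluoromethyl gives a number 4.2 percentage points lower from compound 1 to compound 4 (within the scatter), so none of the four groups shown at this position stands apart from the others in this read-out. No information is available to explain this flat result.

Since all four compounds lie within the scatter of one another at the single concentration tested, the series offers no difference at this position from which a preference among the groups could be read. Going by these compounds, it remains open whether an amine, a carboxylic acid or a longer alkoxy chain on this same aromatic carbon would give a read-out clearly apart from these, and whether any of the four compounds would do so at another concentration.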